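A few compounds are considered here, and "the series" means these few. Any claim that something is new, unique, unknown or untested is made for them only; others in the source may bear on it.

Measured so far:
compound 1, `CC(O)c1nc([C@@H](O)[C@H](O)[C@H](O)CO)c[nH]1`, 22%;
compound 2, `OC[C@@H](O)[C@@H](O)[C@H](O)c1c[nH]c(-c2cscn2)n1`, 12%.

Both numbers come from an in vivo ADME assay on the whole organism (strain 129/SvEvBrd x C57BL/6) for pharmacokinetics, with Mus musculus as the target; on this read-out lower numbers stand for lower oral bioavailability and higher numbers for higher oral bioavailability. Among the measured compounds shown here, of the two measured compounds, compound 2 stands together with compound 1, since the only recorded step is a number 10 percentage points lower from compound 1 to compound 2 (within the scatter). Compound 3, `OC[C@@H](O)[C@@H](O)[C@H](O)c1c[nH]c(-c2cnccn2)n1`, is not yet measured; it differs from compound 2 by pyrazin-2-yl in place of 1,3-thiazol-4-yl on an aromatic carbon. For the measured compounds named here, the one step at this aromatic carbon stayed within the scatter, so the expected outcome for compound 3 in this assay is no step beyond the scatter, namely a number 2 percentage points higher from compound 2 to compound 3 (within the scatter). Compound 3 is therefore estimated at 14%, within 5% to 28%.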

Compound 3, oral bioavailability: 10%
Compound 3: middle estimate off by 4 percentage points, on the high side; low and high end bracket the measured number.
By their numbers in this assay, from the lowest: compounds 3, 2 and 1 (each within the scatter of the next, the first and the last beyond it).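

In this assay, the two aromatic rings on this carbon between two ring nitrogen atoms are not told apart: the exchange of 1,3-thiazol-4-yl for pyrazin-2-yl gives a number 2 percentage points lower from compound 2 to compound 3 (within the scatter). Among the compounds shown here, replacing 1-hydroxyethyl with pyrazin-2-yl gives a number 12 percentage points lower from compound 1 to compound 3 (beyond the scatter), the only step at this position beyond the scatter, and a modest one, while compound 2 stays within the scatter of both neighbours. No evidence bears on the reason for this step. The compounds shown leave open how an amine or a carboxylic acid on this carbon would compare with 1-hydroxyethyl.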